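The source may report more compounds than this note shows. Statements on the series, on what has been measured and on what is new or still open speak of the compounds shown alone.

In a functional assay on the whole organism (plasma) with Mus musculus as the target, with a stated time of 15 days, at a dose of 10 mg/kg by the oral route (on this read-out higher numbers stand for a stronger effect at the one dose given and lower numbers for a weaker effect), compound 3 `Cc1ccc(CN2C(=O)S/C(=C\c3cccc(Br)c3)C2=O)cc1` stands at the top of the three numbers, with 21.3%, but its steps to the other two lie within the scatter. Compound 1 `COc1ccc(/C=C2\SC(=O)N(Cc3ccc(C)cc3)C2=O)cc1` gives 20.6%, and compound 2 `Cc1ccc(CN2C(=O)S/C(=C\c3ccccc3Cl)C2=O)cc1` gives 19.2%; the steps of a number 0.7 percentage points higher from compound 1 to compound 3 (within the scatter) and a number 2.1 percentage points higher from compound 2 to compound 3 (within the scatter) are both within the scatter, as is a number 1.4 percentage points lower from compound 1 to compound 2 (within the scatter). Compound 4 `Cc1ccc(CN2C(=O)S/C(=C\OCc3ccccc3)C2=O)cc1` has not been measured. The change from compound 3 is benzyloxy in place of 3-bromophenyl on a double-bonded chain carbon bound to a double-bonded ring carbon. The three measured steps each swap one group at this same place and none moved the number beyond the scatter, so the expectation for compound 4 is a step of a number 1.3 percentage points lower from compound 3 to compound 4 (within the scatter), not beyond the scatter. Compound 4 is therefore estimated at 20%, between 10% and 30%.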

Compound 4, a percentage reported as activity, at one dose (the size of the read-out at that dose, not a potency): 9.37%
Compound 4: middle estimate off by 10.6 percentage points, on the high side; measured number below the stated range.
By their numbers in this assay, from the lowest: compounds 4, 2, 1 and 3 (each within the scatter of the next, the first and the last beyond it).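

Earlier swaps at this place left the number within the scatter, but here, on a double-bonded chain carbon bound to a double-bonded ring carbon, benzyloxy gives a number 11.9 percentage points lower from compound 3 to compound 4 (beyond the scatter) and a number 11.2 percentage points lower from compound 1 to compound 4 (beyond the scatter) in this assay. Compound 2 is the exception, with a number 9.8 percentage points lower from compound 2 to compound 4 (within the scatter) as its step. So the position does respond to some changes, and nothing available explains this one. Still open, on these data alone, is whether the oxygen or the added carbon of benzyloxy matters. A plain benzyl group or an amine at this place could help separate them.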